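Extending a peptide's benzamide cap with a sulfur heterocycle

A few compounds are considered here, and "the series" means these few. Any claim that something is new, unique, unknown or untested is made for them only; others in the source may bear on it.

Compound 1 `CCCC[C@H](NC(=O)[C@H](CCCCN)NC(=O)[C@H](CCCNC(=N)N)NC(=O)c1ccccc1)C(N)=O` is recorded in an ADME assay for permeability, using PAMPA (a lower number here means that the compound crosses the layer more slowly, a higher number that the compound crosses the layer faster), only as "impermeable" (no number reported), so no single number places it on the scale. Compound 4 `C=CCN1C(=O)/C(=C/c2ccc(C(=O)N[C@@H](CCCNC(=N)N)C(=O)N[C@@H](CCCCN)C(=O)N[C@@H](CCCC)C(N)=O)cc2)SC1=S` differs from it by a group of 11 heavy atoms (7 carbon, 1 nitrogen, 1 oxygen, 2 sulfur; one five-membered non-aromatic ring with 2 hetero atoms) in place of a hydrogen atom, on an aromatic carbon. Among the compounds with values here, no measured step covers exactly this change. The nearest comparison comes from compound 2 `CCCC[C@H](NC(=O)[C@H](CCCCN)NC(=O)[C@H](CCCNC(=N)N)NC(=O)c1ccc(/C=C2\SC(=O)N(Cc3ccc(Cl)cc3)C2=O)cc1)C(N)=O`, which in this assay gives 1.11 10^-6 cm/s, and compound 3 `CCCC[C@H](NC(=O)[C@H](CCCCN)NC(=O)[C@H](CCCNC(=N)N)NC(=O)c1ccc(/C=C2\SC(=O)N(C3CCCCC3)C2=O)cc1)C(N)=O`, which gives 1.69 10^-6 cm/s; both carry a related five-membered ring on an aromatic carbon of the shared core, and the step of a 1.5-fold higher number from compound 2 to compound 3 (0.18 log units; within the scatter) shows how little the group on the ring nitrogen shifts the number. Compound 4 is therefore expected to land in the same region, with an estimated 1.3 10^-6 cm/s and a plausible range from 0.5 10^-6 cm/s to 3.5 10^-6 cm/s.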

Compound 4, apparent permeability: 0.42 10^-6 cm/s
The estimate for compound 4 lay 3.1-fold (0.49 log units) above the measured number; measured number below the stated range.
By their numbers in this assay, from the lowest: compound 4; then compounds 2 and 3 (each within the scatter of the next).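

In this assay, within the data shown here, compound 1 has no number, so no step from it to compound 4 can be read. The compounds shown leave open how far the entering group alone shifts the number, and no data shown offer an explanation.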